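Removing the benzoyl group from compound 3

A few compounds are considered here, and "the series" means these few. Any claim that something is new, unique, unknown or untested is made for them only; others in the source may bear on it.

Compound 1 `Cc1ccc(-c2c(C)c(-c3ccc4c(c3C)CCCO4)c(C(OC(C)(C)C)C(=O)O)c(C)c2NS(C)(=O)=O)cc1C` gives 24000 nM
Compound 2 `Cc1ccc(-c2c(C)c(-c3ccccc3)c(C(OC(C)(C)C)C(=O)O)c(C)c2NS(C)(=O)=O)cc1C` gives > 50000 nM (a limit of the assay)
Compound 3 `Cc1ccc(-c2c(C)c(-c3ccc(C)c(C)c3)c(C(OC(C)(C)C)C(=O)O)c(C)c2NC(=O)c2ccccc2)cc1C` gives 9100 nM

In an ADME assay on MT4 cells (Homo sapiens) for cytotoxicity, read by MTT assay, with a stated time of 4 days (on this read-out higher numbers stand for lower toxicity in this test and lower numbers for higher toxicity in this test), compound 3 gives 9100 nM and holds the lower of the two actual numbers, while compound 1 gives 24000 nM and is its nearest neighbour, higher by more than the scatter. Compound 2 gives > 50000 nM, which is a limit of the assay and not a number.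

Compound 4 `Cc1ccc(-c2c(C)c(-c3ccc(C)c(C)c3)c(C(OC(C)(C)C)C(=O)O)c(C)c2N)cc1C` has yet to be measured. It differs from compound 3 as follows: hydrogen in place of benzoyl on a nitrogen on an aromatic ring. In short, benzamido becomes amino.

Among the measured compounds shown here, no measured step touches that nitrogen. The only one available is an at least 2.0-fold higher number from compound 1 to compound 2 (0.31 log units; beyond the scatter), which lies at a different place, on an aromatic carbon, where a smaller group replaces a larger one. It therefore bears on this change only loosely. On that single precedent, a modest move to a higher number is expected in this assay, with a real chance of no change beyond the scatter. The estimated step is a 2.2-fold higher number from compound 3 to compound 4 (0.34 log units; beyond the scatter), and it remains uncertain. The expected value for compound 4 is 20000 nM, with an estimated range from 8000 nM to 50000 nM.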

Compound 4, half-maximal cytotoxic concentration: 12000 nM
Compound 4: the middle estimate sits 1.7-fold (0.22 log units) above what was measured, within the range that was stated.
By their numbers in this assay, from the lowest: compounds 3, 4 and 1 (each within the scatter of the next, the first and the last beyond it). At a limit, above all of these: compound 2.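

In this assay the benzoyl group on this nitrogen proves unnecessary for the reading seen with compound 3, since the change from benzamido to amino gives a 1.3-fold higher number from compound 3 to compound 4 (0.12 log units; within the scatter) and stays inside the usual scatter. This is the first step shown on the nitrogen on an aromatic ring, and it differs from the only earlier step, an at least 2.0-fold higher number from compound 1 to compound 2 (0.31 log units; beyond the scatter) on an aromatic carbon, which goes beyond the scatter. Compound 2 is still the only compound at a limit of the assay, and neither compound 3 nor compound 4 joins it: the limit of > 50000 nM in this assay, at which 1 of the 4 values shown sits.

As far as these compounds go, whether an acetyl group, a longer acyl chain or a methylamino group on this nitrogen would read like compound 3 and compound 4 remains open. From the compounds shown here alone, it is also open whether benzamido to amino would give the same small step on a core carrying a different aromatic group in place of the dimethylphenyl of these two compounds, as this single pair speaks only for its own core.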